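A few compounds are considered here, and "the series" means these few. Any claim that something is new, unique, unknown or untested is made for them only; others in the source may bear on it.

Compound 1 `O=C(O)c1ccccc1-c1ccc(CCc2ncc(CCC3CCCCC3)[nH]2)cc1` gives the lowest number of the three measured compounds in an in vitro functional assay on cells for agonist activity at Bombesin receptor subtype-3 (Mus musculus), read by luminescence and calcium flux (a higher number here means that more compound is needed for the effect, a lower number that less compound is needed), at 33 nM. Compound 2 `CCCCc1cnc(C(CCCO)Cc2ccc(-c3ccccc3C(=O)O)cc2)[nH]1` gives 238 nM and compound 3 `CCCCc1cnc(C(CC)Cc2ccc(-c3ccccc3C(=O)O)cc2)[nH]1` gives 340 nM; the step of a 1.4-fold higher number from compound 2 to compound 3 (0.15 log units; within the scatter) concerns a hydroxymethyl on the chain, a different place from the change followed here. Compound 4 `O=C(O)c1ccccc1-c1ccc(CCc2ncc(CC3CCC3)[nH]2)cc1` differs from compound 1 by cyclobutyl in place of cyclohexylmethyl on a saturated chain carbon bound to an aromatic carbon. Among the compounds with values here, no measured step alters the group on the saturated chain carbon bound to an aromatic carbon, so nothing measured bears directly on this change, and the expectation rests on the value of compound 1 alone, with a wide range. Compound 4 is expected to give about 150 nM, between 35 nM and 700 nM. This amounts to an expected 4.5-fold higher number from compound 1 to compound 4 (0.66 log units; beyond the scatter).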

Compound 4, half-maximal effective concentration: 7.1 nM
For compound 4 the middle estimate is 21-fold (1.32 log units) above the measured one, and the stated range ends above it.
By their numbers in this assay, from the lowest: compound 4; then compound 1; then compounds 2 and 3 (each within the scatter of the next).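

Compound 4 carries cyclobutyl, with 4 heavy atoms, in place of the 7 of cyclohexylmethyl, and this gives a 4.6-fold lower number from compound 1 to compound 4 (0.67 log units; beyond the scatter) in this assay. Within the data shown here, this is the first view of this position, and it shows that the larger cyclohexylmethyl group is not required for a low number. Nothing at hand explains the step. Going by these compounds, the ring and the length of the link to it change together here, so their shares remain open. On these data alone, whether cyclopentyl or a plain butyl chain at this place would give a still lower number also remains open.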